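Cytotoxicity on MDCK Cells: From Sulfone to Sulfonic Acid

The compounds below may be only part of what the source reports. "The series", "measured", "known", "first", "only" and "open" are said of these compounds alone.

Measured compounds:
- Compound 1, `CCC(CC)O[C@@H]1C=C(S(=O)(=O)CCc2ccncc2)C[C@H](N)[C@H]1NC(C)=O`: "not determined" (no result reported)
- Compound 2, `CCC(CC)O[C@@H]1C=C(S(=O)(=O)CCc2ccncc2)C[C@H](NC(=N)N)[C@H]1NC(C)=O`: > 100000 nM

Two compounds of this series share a common core and differ in the group attached to one ring-nitrogen position. Among the measured compounds shown here, for compound 1 no result was reported in an ADME assay on MDCK cells (Canis lupus familiaris) for cytotoxicity, with a stated time of 48 h (a higher number here means that more compound is tolerated, a lower number that less compound is tolerated), so the only number at hand comes from compound 2. In this assay compound 2 gives > 100000 nM, and this is a limit of the assay rather than a measured number. Its value therefore sits at the limit of > 100000 nM in this assay, at which 1 of the 2 values shown sits; how much further the true value lies cannot be read from the data.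

Compound 3, `CCC(CC)O[C@@H]1C=C(S(=O)(=O)O)C[C@H](NC(=N)N)[C@H]1NC(C)=O`, has not been measured. It differs from compound 2 in one place: hydroxy in place of 2-(pyridin-4-yl)ethyl on a sulfonyl sulfur. For the measured compounds named here, with only a limit known for compound 2 and no measured step to compare against, there is nothing to suggest a shift in either direction. The expected step is a number no higher from compound 2 to compound 3 (the limit leaves the size open), that is, none beyond the usual scatter. On that basis compound 3 is estimated at 100000 nM, in the range 30000 nM to 300000 nM, and most likely the assay will again report only a limit.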

Compound 3, half-maximal cytotoxic concentration: > 100000 nM
Compound 3 ended at the assay's limit; the forecaster's own chance of this, stated with the estimate: 85%; the middle value lies on the limit itself.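

No step can be read between compound 2 and compound 3, as both end at the same limit of the assay: the limit of > 100000 nM in this assay, at which 2 of the 3 values shown sit.

What the compounds shown leave open is how far beyond that limit each true value lies in this assay and so whether hydroxy in place of 2-(pyridin-4-yl)ethyl on a sulfonyl sulfur changes the tolerated concentration at all.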